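From Bromo to Fluoro: Expecting Little Change

The compounds below may be only part of what the source reports. "The series", "measured", "known", "first", "only" and "open" are said of these compounds alone.

Of the compounds shown here, three built on one shared core have been tested in an assay for inhibition of Intestinal-type alkaline phosphatase (Homo sapiens), read by spectrophotometry, with stated times of 10 min and 20 min; a higher number here means a weaker inhibitor, a lower number a stronger inhibitor. Compound 1 `O=C1/C(=C/c2ccccc2Br)NS(=O)(=O)c2ccccc21` gives 7430 nM. Compound 2 `O=C1/C(=C/c2ccc(Br)cc2)NS(=O)(=O)c2ccccc21` gives 3690 nM, and compound 3 `O=C1/C(=C/c2ccc(Cl)cc2Cl)NS(=O)(=O)c2ccccc21` gives 4960 nM. Within the data shown here, compound 2 gives the lowest of the three numbers, but its neighbours lie close: compound 3 sits within the scatter of it, and the only single-point step, a 2.0-fold lower number from compound 1 to compound 2 (0.30 log units; within the scatter), also lies within the scatter. Among the measured compounds shown here, none of the measured compounds can therefore be called clearly stronger than another.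

Compound 4 `O=C1/C(=C/c2ccc(F)cc2)NS(=O)(=O)c2ccccc21` has not been measured yet. It differs from compound 2 in one place: fluoro in place of bromo on an aromatic carbon. For the measured compounds named here, no measured step exchanges one halogen for another; the only step that bears on the question, a 2.0-fold lower number from compound 1 to compound 2 (0.30 log units; within the scatter), exchanged one bromophenyl for another and stayed within the scatter. Nothing seen so far points to a large shift, so the expected step is small, a 1.4-fold higher number from compound 2 to compound 4 (0.13 log units; within the scatter), within the scatter. Compound 4 is therefore estimated at 5000 nM, most likely between 2000 nM and 12000 nM.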

Compound 4, half-maximal inhibitory concentration: 3060 nM
Estimate against measurement, compound 4: 1.6-fold (0.21 log units) above; the measured number falls inside the stated range.
By their numbers in this assay, from the lowest: compounds 4, 2, 3 and 1 (each within the scatter of the next, the first and the last beyond it).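

Exchanging bromo for fluoro on this aromatic carbon, para to a large group, gives a 1.2-fold lower number from compound 2 to compound 4 (0.08 log units; within the scatter) in this assay, so the two halogens cannot be told apart here, although bromine and fluorine are very different atoms. The step of a 2.4-fold lower number from compound 1 to compound 4 (0.39 log units; beyond the scatter) is the only one among these compounds to pass beyond the scatter, and only modestly, but it alters both the halogen and where it sits, so it cannot show which of the two matters. No measurement available here explains either result.

As far as these compounds go, whether this insensitivity extends beyond halogens remains open, as an amine, a carboxylic acid or a methoxy group on the same carbon could give a very different number. Also open, from the compounds shown here alone, is how fluoro would compare with bromo on the carbon carrying the bromine in compound 1.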